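Trimming the Propyl Chain from Compound 1

The source may hold more compounds than are shown below. What is called first, only, known or untested is meant among the compounds shown, and "the series" means these compounds.

Compound 1 `CCCc1ccc(NC2=CC(=O)c3nc4n(c3C2=O)[C@H]2OC[C@@H](O)[C@H]2OC4)cc1` is an anilino compound on a shared core. In a functional assay on ECa-109 cells for inhibition, with ECa-109 cell line (Homo sapiens) as the target, read by sulforhodamine B assay (on this read-out higher numbers stand for weaker inhibition and lower numbers for stronger inhibition), compound 1 does not reach a number at all: it gives only a limit, > 4000 nM. Compound 2 `CCOc1ccc(NC2=CC(=O)c3c(nc4n3[C@H]3OC[C@@H](O)[C@H]3OC4)C2=O)cc1` sits in the same situation, since in this assay compound 2 also gives only a limit, > 4000 nM. Both results rest at one point, (the limit of > 4000 nM in this assay, at which 2 of the 2 values shown sit), so neither compound stands on a scale of numbers, and no order between them can be read.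

Compound 3 `O=C1C=C(Nc2ccccc2)C(=O)c2c1nc1n2[C@H]2OC[C@@H](O)[C@H]2OC1` has not yet been tested. Its change from compound 1 is hydrogen in place of propyl on an aromatic carbon, which reduces the 4-propylphenyl group to a plain phenyl. For the measured compounds named here, no measured step between any two compounds here shows how much such a change moves this read-out, and with compound 1 already at the limit there is nothing to anchor a shift. The expectation is therefore no step beyond the usual scatter, with compound 3 most likely reported as a limit again. Compound 3 is estimated at 6000 nM, with a range from 2000 nM to 25000 nM. The expected step is a step that the limit leaves unreadable from compound 1 to compound 3.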

Compound 3, half-maximal inhibitory concentration: 4970 nM
The estimate for compound 3 lay 1.2-fold (0.08 log units) above the measured number; low and high end bracket the measured number.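

No step can be read from compound 1 to compound 3, because compound 1 gives only a limit and not a number: the limit of > 4000 nM in this assay, at which 2 of the 3 values shown sit.

Going by these compounds, what stays open is whether swapping the 4-propylphenyl group for phenyl shifts the read-out in this assay at all, and by how much, as compound 3 alone has a number.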